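This account rests on a few compounds, and the source may have more. Where it says the series, first, only, none or still open, it means among the compounds named here.

Compound 1 `O=C1NC(=O)C(Cc2ccc(Oc3ccccc3)cc2)S1` gives 307 nM in a functional assay for agonist activity at Free fatty acid receptor 1 (Homo sapiens), read by FLIPR, in the presence of a further agent that is not named here; a higher number here means that more compound is needed for the effect, a lower number that less compound is needed. For the measured compounds named here, compound 2 `Cc1ccc(Oc2ccc(CC3SC(=O)NC3=O)cc2)nc1` gives 4470 nM in this assay, the highest of the two numbers; its nearest neighbour is compound 1, reached by the single step of a 15-fold higher number from compound 1 to compound 2 (1.16 log units; beyond the scatter), a large one, beyond the scatter. Compound 3 `O=C1NC(=O)C(Cc2ccc(Oc3ccc(Cl)cc3)cc2)S1` has not yet been measured in this assay. It differs from compound 2 in one place: 4-chlorophenyl in place of 5-methylpyridin-2-yl on an oxygen on an aromatic ring. Going by the values given here, only the step from compound 1 to compound 2 bears on this change, and it reverses its direction in kind, taking the six-membered aromatic ring with 1 hetero atom out again and putting a six-membered aromatic ring of carbon only back in, now carrying a chlorine. A return toward the number of compound 1 is therefore expected, a step of about an 18-fold lower number from compound 2 to compound 3 (1.25 log units; beyond the scatter) in this assay. For compound 3 the value in this assay is estimated at 250 nM, with a range from 80 nM to 900 nM.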

Compound 3, half-maximal effective concentration: 240 nM
Beside the measured number, compound 3's estimate is 1.0-fold (0.02 log units) above it; low and high end bracket the measured number.
By their numbers in this assay, from the lowest: compounds 3 and 1 (each within the scatter of the next); then compound 2.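

Chloro in place of hydrogen on an aromatic carbon gives a 1.3-fold lower number from compound 1 to compound 3 (0.11 log units; within the scatter) in this assay, so a chlorine at this place on the phenyl ring is tolerated without a separable shift in the number. 4-Chlorophenyl in place of 5-methylpyridin-2-yl gives a 19-fold lower number from compound 2 to compound 3 (1.27 log units; beyond the scatter), and among the three compounds the high number therefore stands with the 5-methylpyridin-2-yl group alone, while both carbon-only rings give numbers within the scatter of each other. Nothing available gives a reason for either step.

On these data alone, the 5-methylpyridin-2-yl group differs from phenyl in both its ring nitrogen and its methyl, so the part each plays remains open. Unsubstituted pyridin-2-yl and 4-methylphenyl on the same oxygen would separate the two, and whether other substituents, such as methoxy or fluoro, behave like chloro also remains open.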